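A few compounds are considered here, and "the series" means these few. Any claim that something is new, unique, unknown or untested is made for them only; others in the source may bear on it.

Compound 1 `CCC[C@]1(C(=O)N2CC[C@](c3ccc(C(F)(C(F)(F)F)C(F)(F)F)cc3)(S(=O)(=O)c3ccc(F)cc3)C2)CC[C@H](C(=O)O)CC1` carries a carboxylic acid on a cyclohexane ring that also bears a propyl chain, and in an ADME assay on microsomes from liver (Homo sapiens) for metabolic stability, with a stated time of 10 min (on this read-out higher numbers stand for a more stable compound and lower numbers for a less stable compound), compound 1 gives "not determined" (no result reported), so no number stands for it in this assay. The same holds for compound 3 `O=C(N1CC[C@](c2ccc(C(F)(C(F)(F)F)C(F)(F)F)cc2)(S(=O)(=O)c2ccc(F)cc2)C1)C12CCC(C(=O)O)(CC1)OC2`, for which this assay gives "not determined" (no result reported). Among the measured compounds shown here, the only number in the set comes from compound 2 `CO[C@]1(C(=O)N2CC[C@](c3ccc(C(F)(C(F)(F)F)C(F)(F)F)cc3)(S(=O)(=O)c3ccc(F)cc3)C2)CC[C@H](C(=O)O)CC1`, which keeps the carboxylic acid but carries a methoxy group in place of the propyl chain; in this assay compound 2 gives 82%, a high fraction remaining. Compound 4 `NC(=O)[C@H]1CC[C@H](C(=O)N2CC[C@](c3ccc(C(F)(C(F)(F)F)C(F)(F)F)cc3)(S(=O)(=O)c3ccc(F)cc3)C2)CC1` has not yet been measured. It differs from compound 1 at the carbonyl carbon: 4-carbamoylcyclohexyl in place of 4-carboxy-1-propylcyclohexyl on a carbonyl carbon. For the measured compounds named here, with no pair of measured compounds on either side of this change, no step size can be drawn from the data; the expectation rests on the single high number of compound 2. Compound 4 is therefore expected to remain well within the stable region of this assay, at an estimated 75%, with a likely range from 50% to 95%.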

Compound 4, percent of the compound remaining: 100%
Beside the measured number, compound 4's estimate is 25 percentage points below it, and the stated range ends below it.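

In this assay, the place on a carbonyl carbon whose other neighbours are an amide-type nitrogen in a ring now has a readable step: 4-carbamoylcyclohexyl in place of 4-carboxy-1-methoxycyclohexyl gives a number 18 percentage points higher from compound 2 to compound 4 (beyond the scatter). In this pair, then, a high fraction remaining does not depend on the carboxylic acid or the methoxy group, while the change from compound 1 cannot be read, as that compound has no number. Nothing available explains the higher number.

This single step changes the acid-bearing carbon and the methoxy-bearing carbon together, so the compounds shown do not separate the two contributions. They also leave open how this assay would respond to an amine or an ester in place of the carbamoyl group, or to a methoxy group kept alongside it.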